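The compounds below may be only part of what the source reports. "The series", "measured", "known", "first", "only" and "open" are said of these compounds alone.

Measured so far:
compound 1 `O=C(O[C@H]1C[C@H](n2cc(F)c(=O)[nH]c2=O)O[C@@H]1COP(=O)(O)Oc1cccnc1)c1ccccc1` — 15600 nM
compound 2 `C[n+]1cccc(OP(=O)([O-])OC[C@H]2O[C@@H](n3cc(F)c(=O)[nH]c3=O)C[C@@H]2OC(=O)c2ccccc2)c1` — 5750 nM

Compound 1 gives the highest of the two numbers in a functional assay on MRC5 cells (Homo sapiens) for cytotoxicity, read by MTT assay, with a stated time of 48 h; a higher number here means a weaker inhibitor, a lower number a stronger inhibitor; its nearest neighbour is compound 2, and that step was a 2.7-fold lower number from compound 1 to compound 2 (0.43 log units; beyond the scatter), a change on the phosphate side of the shared core.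

Compound 3 `O=c1[nH]c(=O)n([C@H]2C[C@H](O)[C@@H](COP(=O)(O)Oc3cccnc3)O2)cc1F` is not yet measured. It differs from compound 1 in one place: hydrogen in place of benzoyl on an oxygen on a saturated carbon. Within the data shown here, no measured step touches that position; the only step known, from compound 1 to compound 2, changes a different part of the molecule and so says little about what removing the benzoyl will do. Among the measured compounds shown here, with no direct precedent, the expectation for compound 3 is a step of no clear direction, and any shift beyond the scatter would be a surprise, giving an expected step of a 1.3-fold higher number from compound 1 to compound 3 (0.11 log units; within the scatter). The estimated value for compound 3 is therefore 20000 nM, within a range from 6000 nM to 65000 nM.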

Compound 3, half-maximal inhibitory concentration: 8500 nM
The estimate for compound 3 lay 2.4-fold (0.37 log units) above the measured number; the measured number falls inside the stated range.
By their numbers in this assay, from the lowest: compounds 2, 3 and 1 (each within the scatter of the next, the first and the last beyond it).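

Among these compounds, replacing benzoyloxy by hydroxy on the saturated carbon gives a 1.8-fold lower number from compound 1 to compound 3 (0.26 log units; within the scatter) in this assay and this pair is the first direct reading of this position. The benzoyl, with its six-membered aromatic ring of carbon only, can therefore leave this oxygen without a shift beyond the scatter, a finding that rests on this single pair. No available evidence explains this result.

From the compounds shown here alone, whether a different ester on the same oxygen, such as an acetyl group or a longer chain like hexanoyl, would also stay within the scatter remains open. Also open, going by these compounds, is whether removing the benzoyl from compound 2, which differs from compound 1 on the phosphate side, would give a similarly small step.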